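From Compound 3 to Compound 4: Trimming One Nitrogen

The compounds below may be only part of what the source reports. "The series", "measured", "known", "first", "only" and "open" are said of these compounds alone.

Measured compounds in a functional assay on SNB-75 cells (Homo sapiens) for inhibition, read by sulforhodamine B assay, with a stated time of 48 h, tested at 10 uM; on this read-out lower numbers stand for a stronger effect and higher numbers for a weaker effect at the one concentration tested:
compound 1, `COc1cc(Cl)cc(-c2nn(-c3cccc(NC(=O)Nc4ccc(Cl)c(C(F)(F)F)c4)c3)cc2-c2ccncc2)c1`, gives 14.5%
compound 2, `COc1cc(Cl)cc(-c2nn(-c3cccc(NC(=O)Nc4ccc(Cl)c(Cl)c4)c3)cc2-c2ccncc2)c1`, gives 16.2%
compound 3, `COc1cc(Cl)cc(-c2nn(-c3cccc(NC(=O)Nc4cccc(C(F)(F)F)c4)c3)cc2-c2ccncc2)c1`, gives 12.5%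

Compound 3 has the lowest of the three numbers, but its distance to the others is small: a number 2 percentage points lower from compound 1 to compound 3 (within the scatter) and a number 3.7 percentage points lower from compound 2 to compound 3 (within the scatter) both lie within the scatter, as does a number 1.7 percentage points higher from compound 1 to compound 2 (within the scatter). So the three measured compounds cannot be ranked against one another.

Compound 4, `COc1cc(Cl)cc(-c2nn(-c3cccc(NC(=O)c4cccc(C(F)(F)F)c4)c3)cc2-c2ccncc2)c1`, differs from compound 3 in one place: 3-(trifluoromethyl)phenyl in place of (3-(trifluoromethyl)phenyl)amino on a carbonyl carbon. The change thus removes the one hydrogen-bond donor of that end of the molecule while keeping the same 3-(trifluoromethyl)phenyl ring.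

Among the measured compounds shown here, none of the measured steps bears on this change. All three vary only the substituents on the terminal ring, and all three are within the scatter. The data therefore give no guide to what happens when the nitrogen next to the carbonyl carbon is taken out, and the estimate must carry a wide range.

Compound 4 is expected to give roughly 25%, somewhere between 8% and 60%, which is an estimated step of a number 12.5 percentage points higher from compound 3 to compound 4 (beyond the scatter).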

Compound 4, a percentage reported as activity, at one concentration (the size of the read-out at that concentration, not a potency): 53.9%
Beside the measured number, compound 4's estimate is 28.9 percentage points below it; measured number inside the range.
By their numbers in this assay, from the lowest: compounds 3, 1 and 2 (each within the scatter of the next); then compound 4.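

In this assay, among the compounds shown here, taking out the nitrogen that joins the 3-(trifluoromethyl)phenyl ring to the carbonyl carbon gives a number 41.4 percentage points higher from compound 3 to compound 4 (beyond the scatter), the only step here that changes this alone and the first to go beyond the scatter. The steps from the two compounds that also carry different substituents on that ring agree, with a number 37.7 percentage points higher from compound 2 to compound 4 (beyond the scatter) and a number 39.4 percentage points higher from compound 1 to compound 4 (beyond the scatter), so compound 4 has a clearly weaker effect at the concentration tested than all three compounds that keep the nitrogen. This position therefore responds strongly to the change, whereas swaps among chloro, trifluoromethyl and hydrogen on the terminal ring left the numbers within the scatter. Nothing measured here explains the weakening.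

Still open, as far as these compounds go, is whether the atom itself or the hydrogen it carries matters: a methylamino-type link, with a methyl group on that nitrogen, or a methylene group in its place would help separate the two. Also open, from the compounds shown here alone, is whether substituents on the terminal ring, such as a methoxy group, would make a readable difference once the nitrogen is gone.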